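This account rests on a few compounds, and the source may have more. Where it says the series, first, only, none or still open, it means among the compounds named here.

Three compounds share a benzylic chloromethyl group on a phenyl ring that is linked through a methylene to a bicyclic core bearing chlorine, and they were tested in a functional assay on CCRF-CEM cells (Homo sapiens) for cytotoxicity, read by sulforhodamine B assay, with a stated time of 48 h; a lower number here means a stronger inhibitor of growth, a higher number a weaker inhibitor of growth. Compound 1, `ClCc1cccc(Cn2cnc3ncnc(Cl)c32)c1`, gives 6910 nM in this assay. Compound 2, `ClCc1cccc(Cn2cnc3c(Cl)ncnc32)c1`, is built from the same atoms joined differently; how the two cores differ is not broken down here. In this assay compound 2 gives 1900 nM. Compound 3, `ClCc1cccc(Cn2cnc3c(Cl)nc(Cl)nc32)c1`, carries one more chlorine than compound 2, the change being (chloro in place of hydrogen on an aromatic carbon). In this assay compound 3 gives 2690 nM, so the step is a 1.4-fold higher number from compound 2 to compound 3 (0.15 log units; within the scatter). Compound 1 stands highest of the three measured numbers, and its gaps to compound 2 and compound 3 both lie beyond the scatter.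

Compound 4, `ClCc1cccc(Cn2cnc3nc(Cl)nc(Cl)c32)c1`, has not yet been measured. It relates to compound 1 exactly as compound 3 relates to compound 2: the change is chloro in place of hydrogen on an aromatic carbon, and the place of the change is described in the same words in both pairs, so it is the same change. Because a 1.4-fold higher number from compound 2 to compound 3 (0.15 log units; within the scatter) did not move the number beyond the scatter, the step is expected to be small as well, about a 1.2-fold higher number from compound 1 to compound 4 (0.09 log units; within the scatter). Compound 4 is therefore expected to give roughly 8500 nM in this assay, most likely between 4000 nM and 18000 nM.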

Compound 4, concentration for 50% growth inhibition: 1380 nM
Compound 4: middle estimate off by 6.2-fold (0.79 log units), on the high side; the measured number lies below the stated range.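

In this assay, putting chloro in place of hydrogen on the aromatic carbon between two ring nitrogen atoms gives a 5.0-fold lower number from compound 1 to compound 4 (0.70 log units; beyond the scatter), so on the core of compound 1 this small change brings a clear gain in growth inhibition. Set beside the matching pair on the other core, the change does not carry over with the same size: the same change on two cores in this assay, a 1.4-fold higher number (0.15 log units; within the scatter) from compound 2 to compound 3 and a 5.0-fold lower number (0.70 log units; beyond the scatter) from compound 1 to compound 4, 7.1-fold (0.85 log units) apart, beyond the scatter of two such steps. This shows that, in these two pairs, the result of adding the chloro group depends on the core that carries it, so a step measured on one core is a poor guide to the step on the other; it does not show why the cores differ, and two pairs give no rule for any further core.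

At this carbon the compounds shown carry only hydrogen or chloro, so it remains open whether an amine or a methoxy group would also give different results on the two cores. From the compounds shown here alone, all four compounds also keep the same chloromethyl group on the phenyl ring, so it remains open how a hydroxymethyl group or a longer chain in its place would change the numbers on either core.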